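A few compounds are considered here, and "the series" means these few. Any claim that something is new, unique, unknown or untested is made for them only; others in the source may bear on it.

Measured in a functional assay on CHO-K1 cells for antagonist activity at cysteinyl leukotriene receptor 1 (Homo sapiens), read by fluorescence and calcium flux, with stated times of 30 min and 1 h; a lower number here means a stronger inhibitor, a higher number a weaker inhibitor: compound 1 `Cc1c(CCCC(=O)O)c2cccc(/C=C/c3ccc(OCCCCc4c(F)c(F)cc(F)c4F)cc3)c2n1CC(=O)O` gives 2.2 nM; compound 2 `Cc1c(CCCC(=O)O)c2cccc(/C=C/c3ccc(OCCCCc4c(F)cc(F)c(F)c4F)cc3)c2n1CC(=O)O` gives 1.6 nM; compound 3 `Cc1c(Cl)cccc1CCCCOc1ccc(C#Cc2cccc3c(CCC(=O)O)c(C)n(CCCCC(=O)O)c23)cc1` gives 25 nM.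

Compound 2 stands within the scatter of compound 1, while compound 3 lies beyond the scatter from both in this assay. The step now followed leads to compound 4 `Cc1c(CCCC(=O)O)c2cccc(/C=C/c3ccc(OCCCCc4cc(F)c(F)c(F)c4F)cc3)c2n1CC(=O)O`, which differs from compound 2 only as follows: 2,3,4,5-tetrafluorophenyl in place of 2,3,4,6-tetrafluorophenyl on a saturated chain carbon, four bonds along the chain from an oxygen on an aromatic ring. Among the measured compounds shown here, the one measured step that bears on this kind of change is a 1.4-fold lower number from compound 1 to compound 2 (0.14 log units; within the scatter), a move of fluorine around the same ring that stayed within the scatter. Compound 4 is therefore expected to give a number close to that of compound 2, with no step beyond the scatter, that is a 1.3-fold higher number from compound 2 to compound 4 (0.10 log units; within the scatter). The estimate for compound 4 in this assay is 2 nM, expected to fall between 0.9 nM and 4.5 nM.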

Compound 4, half-maximal inhibitory concentration: 0.8 nM
Beside the measured number, compound 4's estimate is 2.5-fold (0.40 log units) above it; measured number below the stated range.
By their numbers in this assay, from the lowest: compounds 4, 2 and 1 (each within the scatter of the next, the first and the last beyond it); then compound 3.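

In this assay, among the compounds shown here, the fluorine pattern on this phenyl ring, on a saturated chain carbon four bonds along the chain from an oxygen on an aromatic ring, now gives a first step beyond the scatter, a 2.8-fold lower number from compound 1 to compound 4 (0.44 log units; beyond the scatter) for 2,3,4,5-tetrafluorophenyl in place of 2,3,5,6-tetrafluorophenyl. The other new step, a 2.0-fold lower number from compound 2 to compound 4 (0.30 log units; within the scatter) on leaving 2,3,4,6-tetrafluorophenyl, does not separate those two compounds. Nothing given here accounts for this difference. Still open, going by these compounds, is how an unsubstituted phenyl or a pyridine ring would read at this position.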